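Adding an Acetyl Group to the Chain of Compound 3

A few compounds are considered here, and "the series" means these few. Any claim that something is new, unique, unknown or untested is made for them only; others in the source may bear on it.

The measured compounds and their values:
compound 1, `C=CCc1cc(C(C)=O)c(O)cc1OCCCCCCCCCCC#N`, 14%
compound 2, `CCc1cc(C(C)=O)c(O)cc1OCCCC(C)(C)C#N`, 46%
compound 3, `C=CCc1cc(C(C)=O)c(O)cc1OCCCCC`, 23%

All three were tested in an assay on isolated protein for binding affinity to leukotriene B4 receptor 1 (Homo sapiens), tested at 1 uM; a lower number here means less inhibition, a higher number more inhibition at the concentration tested (going by the name of the read-out). Compound 3 stands second highest of the three numbers. Its nearest neighbour is compound 1, whose value lies nine points lower, a gap within the scatter; the furthest is compound 2, whose value lies higher by a gap beyond the scatter. Compound 2 differs from compound 3 in more than one place, so its values show only that the two sit apart.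

Compound 4, `C=CCc1cc(C(C)=O)c(O)cc1OCCCCCC(C)=O`, has not yet been measured. Its change from compound 3 is acetyl in place of hydrogen on a saturated chain carbon, five bonds along the chain from an oxygen on an aromatic ring. For the measured compounds named here, one measured step bears on this place in the chain: a number 9 percentage points higher from compound 1 to compound 3 (within the scatter). There, a longer group carrying a nitrile was removed from the same chain carbon, and the number hardly moved. The new step puts a short acetyl group onto that carbon instead. Going by the values given here, by the one comparable step, the change in this assay is expected to stay small, with no clear direction beyond the scatter. Compound 4 is therefore estimated at 22%, in a range from 8% to 40%. This estimate means a step of a number 1 percentage points lower from compound 3 to compound 4 (within the scatter), expected to lie within the scatter.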

Compound 4, a percentage reported as inhibition, at one concentration (the size of the read-out at that concentration, not a potency): 58%
Compound 4: the middle estimate sits 36 percentage points below what was measured, and the stated range ends below it.
By their numbers in this assay, from the lowest: compounds 1 and 3 (each within the scatter of the next); then compound 2; then compound 4.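

In this assay, for the compounds shown here, this chain carbon turns out to be far more sensitive than the earlier compounds suggested, with acetyl in place of hydrogen giving a number 35 percentage points higher from compound 3 to compound 4 (beyond the scatter) in a single change. The identity of the group on this carbon matters, not just whether something is attached: acetyl in place of 5-cyanopentyl gives a number 44 percentage points higher from compound 1 to compound 4 (beyond the scatter), whereas hydrogen in place of 5-cyanopentyl gave only a number 9 percentage points higher from compound 1 to compound 3 (within the scatter) and stayed close to the starting value. No measurement shown here accounts for the jump that acetyl brings.

The compounds leave open whether the rise belongs to the carbonyl itself or to the whole acetyl group, a question that a carboxylic acid, a methyl ester or an amine on the same chain carbon could help to settle, as could a longer ketone chain. Going by these compounds, the read-out also gives the size of the effect at one concentration only, so how potent compound 4 really is remains unknown.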